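The source may hold more compounds than are shown below. What is called first, only, known or untested is meant among the compounds shown, and "the series" means these compounds.

Working notes on the series. Three analogues of the shared core have been measured in a functional assay on PC-3 cells (Homo sapiens) for inhibition; on this read-out lower numbers stand for stronger inhibition and higher numbers for weaker inhibition. Compound 1, `COc1cc2nc(N3CCN(C(=O)c4ccc(C(F)(F)F)cc4)CC3)nc(N)c2cc1OC`, gives only a limit of the assay in this assay, > 100000 nM. Compound 2, `COc1cc2nc(N3CCN(S(=O)(=O)c4ccc(Cl)cc4)CC3)nc(N)c2cc1OC`, gives 23000 nM in this assay. Compound 3, `COc1cc2nc(N3CCN(S(=O)(=O)c4cccc5c(N(C)C)cccc45)CC3)nc(N)c2cc1OC`, gives 29000 nM in this assay. Compound 2 thus supplies one of the two actual numbers in the set, the third value being a limit; compound 2 and compound 3 sit within the usual scatter of each other, so no order between them is read. Among the compounds with values here, the one piece of evidence on the measured values is the limit of > 100000 nM in this assay, at which 1 of the 3 values shown sits, which says nothing about a direction for the step at hand.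

The next compound, compound 4, `CCCCc1ccc(-c2ccc(S(=O)(=O)N3CCN(c4nc(N)c5cc(OC)c(OC)cc5n4)CC3)cc2)cc1`, is to be measured in this assay. Compared with compound 2 the change is 4-butylphenyl in place of chloro on an aromatic carbon. Within the data shown here, no measured pair in the set shares this kind of change, so its effect cannot be read from the data. The step from compound 2 to compound 4 is expected to be a 1.9-fold lower number from compound 2 to compound 4 (0.28 log units; within the scatter), a moderate move, with the direction uncertain. For compound 4 the estimate in this assay is 12000 nM, in a range from 2500 nM to 60000 nM.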

Compound 4, half-maximal inhibitory concentration: 3400 nM
Estimate against measurement, compound 4: 3.5-fold (0.55 log units) above, and the stated range covers the measured number.
By their numbers in this assay, from the lowest: compound 4; then compounds 2 and 3 (each within the scatter of the next). At a limit, above all of these: compound 1.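

In this assay, within the data shown here, the replacement of chloro by 4-butylphenyl gives a 6.8-fold lower number from compound 2 to compound 4 (0.83 log units; beyond the scatter), the first change at a single place that can be read. The aromatic carbon para to a large group therefore accepts a substituent of 10 heavy atoms, including a further six-membered aromatic ring of carbon only, and the number falls rather than rises in this one comparison. Nothing measured in the set bears on why the step runs in this direction.

With only chloro and 4-butylphenyl compared at this position, the compounds shown do not separate the contribution of the added phenyl ring from that of the butyl chain, and an unsubstituted phenyl or a 4-methylphenyl would address that question directly. Also open, as far as these compounds go, is whether a longer chain, or an amine or a carboxylic acid at the end of the chain, would take the number lower still or reverse the step.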